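A few compounds are considered here, and "the series" means these few. Any claim that something is new, unique, unknown or untested is made for them only; others in the source may bear on it.

Compound 1, `CCCSc1nc(N)nc2c1ncn2/C=C1/CC1(CO)CO`, gives 98000 nM in an ADME assay on CCRF-HSB-2 cells (Homo sapiens) for cytotoxicity, with a stated time of 7 days; a lower number here means that less compound is tolerated, a higher number that more compound is tolerated. Compound 2, `CCCCCCSc1nc(N)nc2c1ncn2/C=C1/CC1(CO)CO`, gives 60000 nM in this assay. Compound 3, `CSc1nc(N)nc2c1ncn2/C=C1/CC1(CO)CO`, reaches only a limit of the assay, > 100000 nM, in this assay.

Among the two plain numbers compound 1 has the highest; the nearest is compound 2, with a 1.6-fold lower number from compound 1 to compound 2 (0.21 log units; within the scatter). Compound 3 sits at the limit of > 100000 nM in this assay, at which 1 of the 3 values shown sits, so its step from compound 1, an at least 1.0-fold higher number from compound 1 to compound 3 (0.00 log units; that floor lies within the scatter), is known only as a floor, as is an at least 1.6-fold higher number from compound 2 to compound 3 (0.22 log units; that floor lies within the scatter).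

Compound 4, `Nc1nc(SCc2ccccc2)c2ncn(/C=C3/CC3(CO)CO)c2n1`, differs from compound 1 by phenyl in place of ethyl on a saturated chain carbon bound to a sulfur; read one bond further out, propylsulfanyl becomes benzylsulfanyl. Among the compounds with values here, the steps that bear on this change are the ones that alter the chain on the sulfur: a 1.6-fold lower number from compound 1 to compound 2 (0.21 log units; within the scatter) lengthens it, and an at least 1.0-fold higher number from compound 1 to compound 3 (0.00 log units; that floor lies within the scatter) and an at least 1.6-fold higher number from compound 2 to compound 3 (0.22 log units; that floor lies within the scatter) shorten it, all within the scatter or floors inside it. None of these changes moved the number in this assay beyond the scatter, so for compound 4 no step beyond the scatter is expected in either direction. Compound 4 is therefore expected to give 70000 nM, within 25000 nM to 200000 nM, meaning an estimated 1.4-fold lower number from compound 1 to compound 4 (0.15 log units; within the scatter).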

Compound 4, half-maximal cytotoxic concentration: > 100000 nM
Compound 4: only a limit was reported; the forecaster's own chance of this, stated with the estimate: 35%; at least 1.4-fold (0.15 log units) between middle value and limit.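

The new feature is an aromatic ring in place of a plain chain: phenyl in place of ethyl on a saturated chain carbon bound to a sulfur, and in this assay compound 4 gives > 100000 nM, which is a limit of the assay. The steps to it are floors only, an at least 1.0-fold higher number from compound 1 to compound 4 (0.00 log units; that floor lies within the scatter) and an at least 1.6-fold higher number from compound 2 to compound 4 (0.22 log units; that floor lies within the scatter), so benzylsulfanyl shows no sign of more cytotoxicity than the plain chains on the sulfur, but neither floor shows a real gain. The step between compound 3 and compound 4 cannot be read, and these two compounds cannot be ranked against each other: the limit of > 100000 nM in this assay, at which 2 of the 4 values shown sit.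

From the compounds shown here alone, whether any group on this sulfur can move the number beyond the scatter remains open, for example a chain ending in an amine or a carboxylic acid. Going by these compounds, it is also open how a substituent such as chlorine on the phenyl ring would read in this assay, and how far above the limit compound 3 and compound 4 truly lie.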